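From pyridin-4-yl to 1H-benzimidazol-1-yl: one ring group swapped

The source may hold more compounds than are shown below. What is called first, only, known or untested is meant among the compounds shown, and "the series" means these compounds.

Compound 1 `CCN(c1ccc(C#N)c(Cl)c1)c1cc(-c2ccncc2)ccc1C` – 2900 nM
Compound 2 `N#Cc1ccc(N2CCc3cc(-c4cncnc4)ccc32)cc1C(F)(F)F` – "not determined" (no result reported)

Among the measured compounds shown here, in a functional assay on VCaP cells (Homo sapiens) for antiproliferative activity, read by CCK-8 assay, with a stated time of 6 days (on this read-out lower numbers stand for stronger inhibition and higher numbers for weaker inhibition), compound 1 gives 2900 nM and this is the only number available, so it cannot yet be ranked against anything. For compound 2 the entry reads "not determined" (no result reported) and offers no comparison.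

Compound 3 `CCN(c1ccc(C#N)c(Cl)c1)c1cc(-n2cnc3ccccc32)ccc1C` keeps the core of compound 1 but carries 1H-benzimidazol-1-yl in place of pyridin-4-yl on an aromatic carbon, para to a methyl group (1H-benzimidazol-1-yl in place of pyridin-4-yl on an aromatic carbon). For the measured compounds named here, no measured pair of compounds shows what a swap like this does in this assay, so no direction can be argued and no step beyond the scatter is expected. The expected change is a 1.5-fold lower number from compound 1 to compound 3 (0.16 log units; within the scatter) and it rests only on compound 1 at 2900 nM as the starting point. For compound 3 the estimated value is 2000 nM with an expected range from 400 nM to 10000 nM.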

Compound 3, half-maximal inhibitory concentration: 8560 nM
The estimate for compound 3 lay 4.3-fold (0.63 log units) below the measured number, within the range that was stated.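

In this assay, the step is a 3.0-fold higher number from compound 1 to compound 3 (0.47 log units; beyond the scatter), a modest move towards weaker inhibition that lies beyond the usual scatter. Among the compounds shown here, this is the first sign that the aromatic carbon para to a methyl group is not indifferent to the ring group it carries: 1H-benzimidazol-1-yl is tolerated there, but it does less well than pyridin-4-yl. Nothing available explains this difference, and a single pair cannot separate the effect of the added ring from that of the extra ring nitrogen.

Still open, on these data alone, is how this position would respond to a plain phenyl ring, or to a group without a ring, such as an amine or a carboxylic acid. As far as these compounds go, compound 2 has no reported result and adds no comparison, so it remains unknown whether this swap would have a similar effect on a different core.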